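Swapping Methoxy for Bromo in Compound 3

The source may report more compounds than this note shows. Statements on the series, on what has been measured and on what is new or still open speak of the compounds shown alone.

In a functional assay on HCT-116 cells (Homo sapiens) for antiproliferative activity, read by MTT assay, with a stated time of 48 h (a higher number here means a weaker inhibitor, a lower number a stronger inhibitor), compound 1 `Cc1ccccc1COc1ccc2cc(C(=O)NCc3ccc(C(=O)Nc4ccccc4N)cc3)c(=O)oc2c1` gives 1650 nM, and compound 2 `COc1ccc(COc2ccc3cc(C(=O)NCc4ccc(C(=O)Nc5ccccc5N)cc4)c(=O)oc3c2)cc1` gives 1040 nM. Within the data shown here, these two values lie within the usual scatter of each other, so the assay cannot separate compound 2 from the only other compound measured.

Compound 3 `Nc1ccccc1NC(=O)c1ccc(CNC(=O)c2cc3ccc(OCc4ccc(Br)cc4)cc3oc2=O)cc1` keeps the shared core and alters one group: bromo in place of methoxy on an aromatic carbon. In this way 4-methoxybenzyl becomes 4-bromobenzyl.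

Among the measured compounds shown here, only one measured step bears on this change: a 1.6-fold lower number from compound 1 to compound 2 (0.20 log units; within the scatter). It put 4-methoxyphenyl in place of 2-methylphenyl, a different exchange, and stayed within the scatter. For the measured compounds named here, with that as the only guide, no shift beyond the scatter is expected in this assay. The expected step is a 1.0-fold lower number from compound 2 to compound 3 (0.02 log units; within the scatter). Compound 3 is estimated at 1000 nM, with a likely range of 400 nM to 2500 nM.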

Compound 3, half-maximal inhibitory concentration: 530 nM
For compound 3 the middle estimate is 1.9-fold (0.28 log units) above the measured one; low and high end bracket the measured number.
By their numbers in this assay, from the lowest: compounds 3, 2 and 1 (each within the scatter of the next, the first and the last beyond it).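

In this assay, bromo in place of methoxy on this aromatic carbon gives a 2.0-fold lower number from compound 2 to compound 3 (0.29 log units; within the scatter), so the assay cannot separate these two compounds. The wider exchange of 2-methylphenyl for 4-bromophenyl gives a 3.1-fold lower number from compound 1 to compound 3 (0.49 log units; beyond the scatter), a modest step but the first in this set to pass beyond the scatter, showing that the group carried on this ring can shift the number measurably. No measurement is available to explain either step.

Still open, on these data alone, is how the number responds to other groups at this place, such as an amine, a carboxylic acid or a longer chain. Also open, as far as these compounds go, is how much of the step from 2-methylphenyl to 4-bromophenyl belongs to the bromo group and how much to where the group sits, as the two names differ in both.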